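The compounds below may be only part of what the source reports. "The series", "measured", "known", "first", "only" and "open" are said of these compounds alone.

Compound 2 `O=C(Nc1sc2c(c1C(=O)NNc1ccc(Br)cc1)CCCCC2)NS(=O)(=O)c1ccccc1` gives in a functional assay on MCF7 cells (Homo sapiens) for inhibition, with a stated time of 48 h (on this read-out lower numbers stand for stronger inhibition of growth and higher numbers for weaker inhibition of growth), only a limit, > 100000 nM. Compound 1 `CN1CCN(C(=O)c2c(NC(=O)NS(=O)(=O)c3ccccc3)sc3c2CCCCC3)CC1` gives in this assay likewise only a limit, > 100000 nM. The step that the two limits leave unreadable from compound 1 to compound 2 therefore cannot be read, and the limit of > 100000 nM in this assay, at which 2 of the 2 values shown sit, shows where both values sit. Compound 3 `O=C(Nc1sc2c(c1C(=O)N1CCN(c3ccccc3)CC1)CCCCC2)NS(=O)(=O)c1ccccc1` differs from compound 2 by 4-phenylpiperazin-1-yl in place of ((4-bromophenyl)amino)amino on a carbonyl carbon. Among the measured compounds shown here, no measured step bears on this change, so no direction can be drawn from the two measured compounds. For compound 3 the expected value in this assay is 100000 nM, with a range from 30000 nM to 300000 nM. The step this estimate implies is a number no higher from compound 2 to compound 3 (the limit leaves the size open), which is expected rather than measured.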

Compound 3, concentration for 50% growth inhibition: > 100000 nM
Compound 3: no number, only a limit (the forecaster's own chance of this, stated with the estimate: 70%); the middle value lies on the limit itself.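

No step among compound 1, compound 2 and compound 3 can be read in this assay, as each gives only a limit: the limit of > 100000 nM in this assay, at which 3 of the 3 values shown sit.

The compounds shown leave open whether any change on the carbonyl carbon alters growth inhibition in this assay.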